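Tert-Butyl Substitution on Two Weakly Antiproliferative Acids

The source may hold more compounds than are shown below. What is called first, only, known or untested is meant among the compounds shown, and "the series" means these compounds.

Compound 1 `O=C(O)CC(NC(=O)c1ccc(Cl)cc1Cl)c1ccccc1` and compound 2 `O=C(O)CC(NS(=O)(=O)c1ccccc1)c1ccccc1` are both amino acids carrying an aromatic ring, but they differ in the acyl group on the nitrogen; the difference between the two cores is not broken down here. Compound 3 `CC(C)(C)c1ccc(C(CC(=O)O)NC(=O)c2ccc(Cl)cc2Cl)cc1` is derived from compound 1 by tert-butyl in place of hydrogen on an aromatic carbon. Compound 4 `CC(C)(C)c1ccc(C(CC(=O)O)NS(=O)(=O)c2ccccc2)cc1` is derived from compound 2 by tert-butyl in place of hydrogen on an aromatic carbon. The place of the new group is described in the same words for both pairs, so this is the same change made twice.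

In a functional assay on MDA-MB-436 cells (Homo sapiens) for antiproliferative activity, read by MTT assay, with a stated time of 24 h (on this read-out higher numbers stand for weaker inhibition and lower numbers for stronger inhibition), compound 1 gives 78200 nM. Compound 3 reaches only a limit of this assay, > 100000 nM. Compound 2 likewise reaches only a limit of this assay, > 100000 nM. The measured change from compound 1 to compound 3 therefore shows an at least 1.2-fold higher number from compound 1 to compound 3 (0.10 log units; that floor lies within the scatter), and the size of that step cannot be pinned down further because of the limit of > 100000 nM in this assay, at which 2 of the 3 values shown sit.

For compound 4 the corresponding step is expected to be a step that the limit leaves unreadable from compound 2 to compound 4, resting on the fact that compound 2 already sits at the limit > 100000 nM and that the same change moved compound 3 to > 100000 nM. Compound 4 is thus expected to give roughly 200000 nM, plausibly between 80000 nM and 600000 nM, and will most likely be reported only as a limit.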

Compound 4, half-maximal inhibitory concentration: > 100000 nM
Compound 4: no number, only a limit (the forecaster's own chance of this, stated with the estimate: 85%); the middle value does not contradict the limit.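

No new step can be read between compound 2 and compound 4, because both give only a limit and not a number: the limit of > 100000 nM in this assay, at which 3 of the 4 values shown sit.

What the compounds shown leave open is the true strength of compound 2, compound 3 and compound 4 in this assay, and so whether tert-butyl in place of hydrogen on an aromatic carbon changes anything on the core of compound 2.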